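This account rests on a few compounds, and the source may have more. Where it says the series, first, only, none or still open, it means among the compounds named here.

In an ADME assay on BJ cells (Homo sapiens) for cytotoxicity, with a stated time of 72 h (on this read-out lower numbers stand for an effect already at smaller amounts and higher numbers for an effect only at larger amounts of compound), compound 1, `C=C[C@@](C)(/C=C/c1ccc(OCc2ccccc2)cc1)CCC=C(C)C`, gives > 36600 nM, which is a limit of the assay and not a number. Compound 2, `C=C[C@@](C)(/C=C/c1ccc(O)c(CO)c1)CCC=C(C)C`, gives > 36600 nM, and this too is only a limit. Compound 2 therefore stands at the limit of > 36600 nM in this assay, at which 2 of the 2 values shown sit, and no exact number is known for it.

Compound 3, `C=C[C@@](C)(/C=C/c1ccc(O)c(C=O)c1)CCC=C(C)C`, has not yet been measured. It differs from compound 2 in one place: formyl in place of hydroxymethyl on an aromatic carbon.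

Among the measured compounds shown here, no measured pair of compounds shows what a single change does in this assay, so any forecast here is uncertain. For the measured compounds named here, the only guide is that both measured compounds sit at the same limit, which points to a small shift at most, and compound 3 may well report only a limit too. The estimated change, an at least 1.2-fold lower number from compound 2 to compound 3 (0.08 log units; that floor lies within the scatter), is a modest step toward lower numbers that may not clear the usual scatter. For compound 3 the expected value is 30000 nM, with an estimated range from 12000 nM to 40000 nM.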

Compound 3, half-maximal effective concentration: > 36600 nM
Compound 3 ended at the assay's limit (the forecaster's own chance of this, stated with the estimate: 55%); at least 1.2-fold (0.08 log units) between middle value and limit.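

Among the compounds shown here, compound 2 and compound 3 both report only a limit of the assay, so no step between them can be read in this assay: the limit of > 36600 nM in this assay, at which 3 of the 3 values shown sit.

The compounds shown leave open whether formyl in place of hydroxymethyl on an aromatic carbon changes the read-out at all, and at what concentration compound 1, compound 2 or compound 3 would produce an effect.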